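Compound 3 to compound 4: one further fluoro

The compounds below may be only part of what the source reports. "The series", "measured", "known", "first", "only" and "open" are said of these compounds alone.

In an ADME assay on HEK293 cells (Homo sapiens) for cytotoxicity, with a stated time of 72 h (a lower number here means that less compound is needed, a higher number that more compound is needed for the effect), compound 1 `O=C(Nc1nc2ccc(F)cc2s1)c1cc([N+](=O)[O-])ccc1Cl` gives > 27000 nM, which is a limit of the assay and not a number. Among the measured compounds shown here, compound 2 `O=C(Nc1nc(-c2ccc(Cl)cc2)cs1)c1cc([N+](=O)[O-])ccc1Cl` gives 15000 nM and compound 3 `O=C(Nc1nc(-c2cccc(F)c2)cs1)c1cc([N+](=O)[O-])ccc1Cl` gives 8700 nM, so compound 3 stands within the scatter of the only other number. For the measured compounds named here, the one measured step is a 1.7-fold lower number from compound 2 to compound 3 (0.24 log units; within the scatter), with 3-fluorophenyl in place of 4-chlorophenyl on an aromatic carbon.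

Compound 4 `O=C(Nc1nc(-c2ccc(F)c(F)c2)cs1)c1cc([N+](=O)[O-])ccc1Cl` differs from compound 3 by fluoro in place of hydrogen on an aromatic carbon, taking 3-fluorophenyl to 3,4-difluorophenyl (fluoro in place of hydrogen on an aromatic carbon). Going by the values given here, the step from compound 2 to compound 3 is the only measured guide to a change on this aryl group, and at a 1.7-fold lower number from compound 2 to compound 3 (0.24 log units; within the scatter) it stayed small. No step beyond the scatter is therefore expected in this assay, and no direction can be favoured. The expected step is a 1.0-fold higher number from compound 3 to compound 4 (0.01 log units; within the scatter). For compound 4 the estimated value is 9000 nM, with an expected range of 4000 nM to 20000 nM.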

Compound 4, half-maximal effective concentration: 8300 nM
The estimate for compound 4 lay 1.1-fold (0.04 log units) above the measured number, and the stated range covers the measured number.
By their numbers in this assay, from the lowest: compounds 4, 3 and 2 (each within the scatter of the next). At a limit, above all of these: compound 1.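

In this assay, fluoro in place of hydrogen at this place, ortho to a fluoro group and para to a large group, gives a 1.0-fold lower number from compound 3 to compound 4 (0.02 log units; within the scatter). Among the compounds shown here, the only earlier step on this aryl group exchanged one whole substituted phenyl for another, whereas this one isolates a single added fluoro at a single place, and the number holds within the scatter; the wider exchange, with 3,4-difluorophenyl in place of 4-chlorophenyl, gives a 1.8-fold lower number from compound 2 to compound 4 (0.26 log units; within the scatter), so all three aryl groups read alike in this assay. Nothing measured here speaks to a cause for this flat reading.

On these data alone, whether an amine, a carboxylic acid or a methoxy group at this same place would move the number beyond the scatter stays open. The unsubstituted phenyl group also stands outside these compounds, so the effect of the first fluoro alone remains unread.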